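Changing the Group on the Aromatic Nitrogen

This account rests on a few compounds, and the source may have more. Where it says the series, first, only, none or still open, it means among the compounds named here.

Measured compounds:
Compound 1 `O=C(O)C1=Cc2ccccc2OC1(OCc1cc(-c2ccc(F)cc2)no1)C(F)(F)F` gives 64200 nM.
Compound 2 `CCOC(=O)C1=Cc2ccccc2OC1(OCc1cn(-c2ccc(C)cc2)nn1)C(F)(F)F` gives 26700 nM.

Of the compounds shown here, two have been measured in a functional assay on MCF7 cells (Homo sapiens) for inhibition, read by MTT assay, with a stated time of 24 h; a higher number here means a weaker inhibitor, a lower number a stronger inhibitor. Going by the values given here, of these, compound 2 has the lower number, and the only neighbour, compound 1, sits at a higher number that lies beyond the usual scatter. Among the compounds with values here, with just two values and no step between compounds that differ in a single place, nothing links a particular part of the structures to the difference.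

Compound 3 `CCOC(=O)C1=Cc2ccccc2OC1(OCc1cn(CC(=O)Nc2ccccc2Br)nn1)C(F)(F)F` has not been measured. Compared with compound 2 it differs in one place: ((2-bromophenyl)carbamoyl)methyl in place of 4-methylphenyl on an aromatic nitrogen. The group that leaves has no hydrogen-bond donor or acceptor; the group that enters brings one of each, together with a bromine, and is larger.

Since no comparable step is recorded, the size and direction of the change cannot be anchored in shown data. The account treats the step as expected to fall within or close to the scatter, in either direction, as a 1.1-fold lower number from compound 2 to compound 3 (0.03 log units; within the scatter). Compound 3 is therefore estimated in this assay at 25000 nM, within a range from 8000 nM to 80000 nM.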

Compound 3, half-maximal inhibitory concentration: > 150000 nM
Compound 3: only a limit was reported; the forecaster's own chance of this, stated with the estimate: 10%; middle value at least 6.0-fold (0.77 log units) from the limit.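

In this assay compound 3 gives > 150000 nM, which is a limit of the assay and not a number. With ((2-bromophenyl)carbamoyl)methyl in place of 4-methylphenyl on the aromatic nitrogen, the account now has its first change in a single place, and it reads as an at least 5.6-fold higher number from compound 2 to compound 3 (0.74 log units; beyond the scatter), so the group on this nitrogen is not interchangeable in this series and this replacement goes towards the weaker end of what is shown. The step has a lower bound but no upper one, and how much weaker compound 3 really is cannot be read from the result: the limit of > 150000 nM in this assay, at which 1 of the 3 values shown sits.

The entering group differs from 4-methylphenyl in several ways at once, with its methylene link, carbonyl, amide hydrogen and bromine, and the compounds shown do not separate these parts from one another. Going by these compounds, it stays open whether a (phenylcarbamoyl)methyl group without the bromine, a 2-bromophenyl group on the same nitrogen, or a simple benzyl group would stay near compound 2 or follow compound 3, and whether any group here can give a lower number than compound 2.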